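A few compounds are considered here, and "the series" means these few. Any claim that something is new, unique, unknown or untested is made for them only; others in the source may bear on it.

Three compounds of the series have numbers in a functional assay on NCI-H460 cells (Homo sapiens) for inhibition, read by MTT assay, with a stated time of 72 h; on this read-out lower numbers stand for stronger inhibition and higher numbers for weaker inhibition. Compound 1 `CCN(CC)CCCn1c(=O)c(=Cc2ccc(F)cc2F)s/c1=C1\C(=O)Nc2ccc(Cl)cc21` gives 6100 nM; compound 2 `COc1ccc(C=c2s/c(=C3\C(=O)Nc4cc(F)ccc43)n(CCN(C)C)c2=O)cc1` gives 2200 nM; compound 3 `CN(C)CCn1c(=O)c(=Cc2ccc(O)cc2)s/c1=C1\C(=O)Nc2ccc(F)cc21` gives 1270 nM. The number for compound 3 is the lowest of the three, but compound 2 lies within the usual scatter of it, so no order between those two can be read; only compound 1 stands beyond the scatter, at the higher number. Compound 4 `CN(C)CCn1c(=O)c(=Cc2ccc(O)cc2)s/c1=C1\C(=O)Nc2ccc(Br)cc21` differs from compound 3 in one place: bromo in place of fluoro on an aromatic carbon. Within the data shown here, no measured pair shows this change, so nothing in these data fixes its size or direction. The expectation is a step none beyond the scatter, a 1.2-fold lower number from compound 3 to compound 4 (0.06 log units; within the scatter). Compound 4 is thus estimated at 1100 nM in this assay, with a range from 400 nM to 3200 nM.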

Compound 4, half-maximal inhibitory concentration: 1110 nM
Compound 4: the middle estimate sits 1.0-fold (0.00 log units) below what was measured; measured number inside the range.
By their numbers in this assay, from the lowest: compounds 4, 3 and 2 (each within the scatter of the next); then compound 1.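

Bromo in place of fluoro on this aromatic carbon gives a 1.1-fold lower number from compound 3 to compound 4 (0.06 log units; within the scatter) in this assay and is the first step of the series that differs in one place. At this position, the two halogens cannot be told apart in this assay, despite the change from the smaller fluoro to the larger bromo atom. Nothing at hand bears on the reason for this result.

Open, on these data alone, is whether a nitrile or a carboxylic acid on this carbon would stay within the same scatter. Also open, as far as these compounds go, is whether the equivalence of the two halogens holds with other groups elsewhere on the shared core.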